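The source may report more compounds than this note shows. Statements on the series, on what has been measured and on what is new or still open speak of the compounds shown alone.

In a functional assay on MCF7 cells (Homo sapiens) for antiproliferative activity, read by MTT assay, with a stated time of 72 h (on this read-out lower numbers stand for stronger inhibition and higher numbers for weaker inhibition), compound 1 `CCOC(=O)c1cc(=O)c2cc(CSC(=S)N(C(C)C)C(C)C)ccc2o1` gives only a limit, > 25000 nM, so no number stands for it. Compound 2 `CC(C)N(C(=S)SCc1cc(=O)c2ccc(Cl)cc2o1)C(C)C` likewise returns only a limit in this assay, > 25000 nM. Compound 3 `O=c1c(Cl)c(CSC(=S)N2CCCC2)oc2ccccc12`, which carries a pyrrolidin-1-yl on its thiocarbonyl carbon, gives 2300 nM in this assay. Two of the three values shown sit at the limit of > 25000 nM in this assay, at which 2 of the 3 values shown sit, so compound 1 stands at that limit rather than at a number, and only compound 3 has yielded a figure.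

The unmeasured compound 4 `CCOC(=O)c1cc(=O)c2cc(CSC(=S)N3CCCC3)ccc2o1` differs from compound 1 in one place: pyrrolidin-1-yl in place of diisopropylamino on a thiocarbonyl carbon. Among the measured compounds shown here, no measured pair traces this change on the shared core, and compound 3 differs from compound 4 elsewhere in its core as well, so its value is only a hint. The step from compound 1 to compound 4 is expected to be an at least 3.1-fold lower number from compound 1 to compound 4 (0.49 log units; beyond the scatter), towards stronger inhibition but with wide uncertainty. Compound 4 is thus estimated at 8000 nM, within 2000 nM to 30000 nM, and a result reported only as a limit remains quite possible.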

Compound 4, half-maximal inhibitory concentration: > 25000 nM
Compound 4 ended at the assay's limit; the forecaster's own chance of this, stated with the estimate: 40%; middle value at least 3.1-fold (0.49 log units) away from the limit.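

In this assay, compound 1 and compound 4 both end at a limit rather than a number, so no step can be read between them: the limit of > 25000 nM in this assay, at which 3 of the 4 values shown sit. The compounds shown leave open whether pyrrolidin-1-yl in place of diisopropylamino on a thiocarbonyl carbon changes inhibition on this core at all.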